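The compounds below may be only part of what the source reports. "The series", "measured", "known", "first", "only" and "open" are said of these compounds alone.

Measured so far in a functional assay on MCF7 cells (Homo sapiens) for inhibition, read by MTT assay, with a stated time of 72 h; on this read-out higher numbers stand for weaker inhibition and lower numbers for stronger inhibition:
- compound 1 `C=C(Br)C(=O)Nc1cccc(/C=C/C(=O)Nc2ccccc2)c1` gives 27300 nM
- compound 2 `C=C(Br)C(=O)Nc1cccc(/C=C/C(=O)Nc2ccc(F)c(F)c2)c1` gives 2690 nM
- compound 3 `C=C(Br)C(=O)Nc1cccc(/C=C/C(=O)Nc2ccc(C)cc2)c1` gives 2500 nM

Compound 3 (2500 nM) shares the low end of these numbers with compound 2 (2690 nM), and the gap between them is small: a 1.1-fold lower number from compound 2 to compound 3 (0.03 log units; within the scatter). Compound 1 (27300 nM) stands well apart from both.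

The next compound, compound 4 `C=C(Br)C(=O)Nc1cccc(/C=C/C(=O)Nc2ccc(SC(F)(F)F)cc2)c1`, has (trifluoromethyl)sulfanyl in place of methyl on an aromatic carbon, para to a large group ((trifluoromethyl)sulfanyl in place of methyl on an aromatic carbon). Among the compounds with values here, no measured compound carries this group, so the evidence is indirect. Two large steps start from the plain phenyl: a 10-fold lower number from compound 1 to compound 2 (1.01 log units; beyond the scatter) and an 11-fold lower number from compound 1 to compound 3 (1.04 log units; beyond the scatter). Both substituted compounds therefore gave lower numbers than compound 1, and neither goes against this. Within the data shown here, exchanging one substituted phenyl for the other is the closest precedent for the new change, and that step stayed small, as a 1.1-fold lower number from compound 2 to compound 3 (0.03 log units; within the scatter) shows.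

On that basis, no step beyond the scatter is expected, perhaps only a slight drift towards a lower number. The expected step is a 1.3-fold lower number from compound 3 to compound 4 (0.10 log units; within the scatter) in this assay on this estimate. Compound 4 is estimated at 2000 nM with an expected range from 600 nM to 7000 nM for repeat measurements.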

Compound 4, half-maximal inhibitory concentration: 30100 nM
Estimate against measurement, compound 4: 15-fold (1.18 log units) below, outside the stated range (above it).
By their numbers in this assay, from the lowest: compounds 3 and 2 (each within the scatter of the next); then compounds 1 and 4 (each within the scatter of the next).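

In this assay, the substituent on this aromatic carbon, para to a large group, proves decisive: replacing methyl with (trifluoromethyl)sulfanyl gives a 12-fold higher number from compound 3 to compound 4 (1.08 log units; beyond the scatter) and so removes the whole gain that compound 3 held over the plain phenyl. Set against that unsubstituted ring directly, the same group gives a 1.1-fold higher number from compound 1 to compound 4 (0.04 log units; within the scatter) and so leaves compound 4 level with compound 1, which shows that the low numbers of compound 2 and compound 3 do not come with just any substituent on the phenyl ring. The earlier pattern, in which substituted compounds gave lower numbers than compound 1, therefore holds only for compound 2 and compound 3, with compound 4 going against it, and nothing available here explains this sharp difference between two groups at the same place.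

The compounds shown leave open whether a methoxy group, a chlorine atom, a nitrile or an amine at this position would side with compound 3 or with compound 4. They also leave open whether (trifluoromethyl)sulfanyl would behave the same way on a different carbon of the ring.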